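Swapping the Glutamate Tail for a Pyridinylmethyl Group

The source may hold more compounds than are shown below. What is called first, only, known or untested is meant among the compounds shown, and "the series" means these compounds.

Of the compounds shown here, two sharing the same core have been measured in a functional assay on A549 cells (Homo sapiens) for antiproliferative activity, read by MTT assay, with a stated time of 72 h, in the presence of a further agent that is not named here; a lower number here means a stronger inhibitor, a higher number a weaker inhibitor. Compound 1 `Nc1nc2[nH]c(CCSCC(=O)N[C@@H](CCC(=O)O)C(=O)O)cc2c(=O)[nH]1` gives 668 nM. Compound 2 `Nc1nc2[nH]c(CCSCCC(=O)N[C@@H](CCC(=O)O)C(=O)O)cc2c(=O)[nH]1` gives 713 nM, and these two values fall within the usual scatter of each other, so neither compound can be called the stronger or weaker inhibitor on this evidence.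

Compound 3 `Nc1nc2[nH]c(CCSCCC(=O)NCc3ccncc3)cc2c(=O)[nH]1` has not yet been measured. It differs from compound 2 in one place: (pyridin-4-yl)methyl in place of 1,3-dicarboxypropyl on an amide-type nitrogen. Going by the values given here, no step between measured compounds shows what such a change does here, so the expectation rests on the size of the change alone. Most of the tail on the amide-type nitrogen is exchanged, and so a shift in this assay beyond the scatter appears likely, most probably toward a higher number, that is a weaker inhibitor. The step from compound 2 to compound 3 is expected to be a 4.2-fold higher number from compound 2 to compound 3 (0.62 log units; beyond the scatter). For compound 3 the expected value in this assay is 3000 nM, with a plausible range from 800 nM to 15000 nM.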

Compound 3, half-maximal inhibitory concentration: 7870 nM
The estimate for compound 3 lay 2.6-fold (0.42 log units) below the measured number; the measured number falls inside the stated range.
By their numbers in this assay, from the lowest: compounds 1 and 2 (each within the scatter of the next); then compound 3.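

In this assay, the group on the amide-type nitrogen clearly matters: putting (pyridin-4-yl)methyl in place of 1,3-dicarboxypropyl gives an 11-fold higher number from compound 2 to compound 3 (1.04 log units; beyond the scatter), a large step toward a weaker inhibitor. Compounds 1 and 2 both carry 1,3-dicarboxypropyl, so they could not show how much this part of the molecule contributes; compound 3 shows that the shared core and thioether-containing chain do not by themselves preserve the level seen for compound 2. Even so, the change does not abolish the activity, since compound 3 still gives a measurable 7870 nM, but nothing shown here explains the loss.

The change is a wholesale exchange: two carboxylic acids and a defined stereocentre leave, and one six-membered aromatic ring enters, so the contribution of each part cannot be separated. As far as these compounds go, it remains open whether a tail keeping just one carboxylic acid, or a benzyl group or (pyridin-3-yl)methyl in the same place, would give a number closer to that of compound 2 or that of compound 3.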